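Swapping an acyclic carbamate chain for a sulfonylpiperazine amide

The source may hold more compounds than are shown below. What is called first, only, known or untested is meant among the compounds shown, and "the series" means these compounds.

The series shares one core, seen in compound 1 `O=C(CN1CN(c2ccccc2)C2(CCN(C(=O)c3ccc(C4CCCCC4)cc3)CC2)C1=O)N1CCCCC1`, a compound which in an assay on HEK293 cells for displacement of a labelled ligand from NPC1-like intracellular cholesterol transporter 1 (Homo sapiens) (on this read-out higher numbers stand for weaker inhibition and lower numbers for stronger inhibition), gives 1100 nM. Compound 2 `CC(C)(C)OC(=O)NCNC(=O)CN1CN(c2ccccc2)C2(CCN(C(=O)c3ccc(C4CCCCC4)cc3)CC2)C1=O` carries an open carbamate-bearing chain on the same carbonyl carbon and in this assay gives 1700 nM, the second highest of the three numbers; compound 3 `CC(C)(C)OC(=O)NCCCCNC(=O)CN1CN(c2ccccc2)C2(CCN(C(=O)c3ccc(C4CCCCC4)cc3)CC2)C1=O`, with the longer chain, gives 4600 nM. Compound 2 thus sits nearest to compound 1, with a 1.5-fold higher number from compound 1 to compound 2 (0.19 log units; within the scatter), and furthest from compound 3, with a 2.7-fold higher number from compound 2 to compound 3 (0.43 log units; beyond the scatter).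

Compound 4 `CS(=O)(=O)N1CCN(C(=O)CN2CN(c3ccccc3)C3(CCN(C(=O)c4ccc(C5CCCCC5)cc4)CC3)C2=O)CC1` takes the step (4-(methylsulfonyl)piperazin-1-yl in place of (((tert-butoxycarbonyl)amino)methyl)amino on a carbonyl carbon). Among the compounds with values here, two measured steps bear on it. The step from compound 1 to compound 2 shows that exchanging a cyclic amine for the open carbamate chain on this carbonyl moved the number only a little. The step from compound 2 to compound 3 shows that lengthening that chain raised the number modestly. Compound 4 returns to a cyclic amine on the carbonyl, so the author expects the number to come back toward that of compound 1, a small step of a 1.4-fold lower number from compound 2 to compound 4 (0.15 log units; within the scatter) downward, not beyond the scatter. The estimate for compound 4 in this assay is 1200 nM, with a range from 500 nM to 3500 nM.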

Compound 4, half-maximal inhibitory concentration: 6300 nM
The estimate for compound 4 lay 5.3-fold (0.72 log units) below the measured number; the measured number lies above the stated range.
By their numbers in this assay, from the lowest: compounds 1 and 2 (each within the scatter of the next); then compounds 3 and 4 (each within the scatter of the next).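

In this assay, a ring amine on this carbonyl carbon does not by itself keep the number low, since 4-(methylsulfonyl)piperazin-1-yl in place of piperidin-1-yl gives a 5.7-fold higher number from compound 1 to compound 4 (0.76 log units; beyond the scatter), so two ring amides on the same carbonyl carbon can stand apart beyond the scatter. Against the open chain, the exchange gives a 3.7-fold higher number from compound 2 to compound 4 (0.57 log units; beyond the scatter), although the group that leaves and the group that enters hold the same count of heavy atoms, so at this position that count alone does not fix the number. Compound 3 and compound 4 lie within the scatter of each other, which means that a longer carbamate chain and the sulfonyl-bearing ring end up at the same level on this read-out, while compound 1 and compound 2 stay together at the lower numbers.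

From the compounds shown here alone, what remains open is whether the higher number belongs to the methylsulfonyl group or to the piperazine ring itself, a question that a piperazine with a free amine, an acetyl group in place of the methylsulfonyl group, or a morpholine ring on the same carbonyl carbon would bear on. Nothing shown here gives any measured reason for the difference between these groups.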